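Swapping a Cyclic Carbamate for a Cyclic Urea

The compounds below may be only part of what the source reports. "The series", "measured", "known", "first", "only" and "open" are said of these compounds alone.

Compound 1 `C/C(=C\C(=O)Nc1ccc2nc(N3CCC(O)CC3)nc(C)c2c1)c1ccc(Cl)cc1`: 227 nM
Compound 2 `Cc1nc(N2CCC(O)(C3CC3)CC2)nc2ccc(NC(=O)/C=C/c3ccc(C(F)(F)F)cc3)cc12`: 83 nM
Compound 3 `Cc1nc(N2CCC(N3CCOC3=O)CC2)nc2ccc(NC(=O)/C=C/c3ccc(OC(F)(F)F)cc3)cc12`: 31 nM

All three compounds were tested in a functional assay on CHO-K1 cells for antagonist activity at melanin-concentrating hormone receptor 1 (Homo sapiens), read by inositol phosphate accumulation, with stated times of 10 min and 45 min; a higher number here means a weaker inhibitor, a lower number a stronger inhibitor. Among these numbers compound 3 stands lowest, which means it is the strongest inhibitor of the three. Its gap to compound 2, the nearest of the other two, is beyond the usual scatter of this kind of measurement, and its gap to compound 1 is larger still. The three compounds differ from one another in more than one place, so nothing can be said about which single part of the structure accounts for these gaps.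

Compound 4 `Cc1nc(N2CCC(N3CCNC3=O)CC2)nc2ccc(NC(=O)/C=C/c3ccc(OC(F)(F)F)cc3)cc12` has not yet been measured. It differs from compound 3 in one place only: 2-oxoimidazolidin-1-yl in place of 2-oxo-1,3-oxazolidin-3-yl on a saturated ring carbon. Going by the values given here, no measured pair in this set shows the effect of such a change, so there is no direct guide to its size or direction. Among the compounds with values here, with no such step in hand, the expectation is that compound 4 gives a number close to compound 3, with any difference within the scatter. The estimate for compound 4 in this assay is therefore 35 nM, with a range from 12 nM to 100 nM, which corresponds to an expected step of a 1.1-fold higher number from compound 3 to compound 4 (0.05 log units; within the scatter).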

Compound 4, half-maximal inhibitory concentration: 31 nM
For compound 4 the middle estimate is 1.1-fold (0.05 log units) above the measured one, within the range that was stated.
By their numbers in this assay, from the lowest: compounds 3 and 4 (each within the scatter of the next); then compound 2; then compound 1.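

In this assay, going by these compounds alone, the exchange of 2-oxo-1,3-oxazolidin-3-yl for 2-oxoimidazolidin-1-yl gives no change at the digits printed from compound 3 to compound 4 (within the scatter), the first direct reading of a single change at this saturated ring carbon of the piperidine, three ring bonds from the ring nitrogen. The entering ring has 1 hydrogen-bond donor and 1 hydrogen-bond acceptor, whereas the leaving ring has 0 hydrogen-bond donors and 2 hydrogen-bond acceptors, so in this pair that difference in counts comes with no change in the number beyond the scatter. No measurement at hand explains why the two rings read alike.

From the compounds shown here alone, this is a single pair with everything else held the same, so it remains open whether the exchange would read the same way with a different group in place of the trifluoromethoxy group of compound 3 and compound 4. Within the data shown here, also open is how far this ring carbon tolerates other kinds of group, such as a simple amine, a carboxylic acid or an open-chain urea, since the five-membered rings of compound 3 and compound 4 are the only pair that speaks to this position.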